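Swapping the aryl group on compound 2

The source may hold more compounds than are shown below. What is called first, only, known or untested is meant among the compounds shown, and "the series" means these compounds.

Measured in a functional assay on PC-3 cells (Homo sapiens) for antiproliferative activity, read by MTT assay, with a stated time of 48 h; on this read-out higher numbers stand for weaker inhibition and lower numbers for stronger inhibition:
- compound 1 `O=C(/C=C/c1ccc(O)cc1)Nc1cc2c(Nc3ccc(Cl)c(Cl)c3)ncnc2s1` gives 300 nM
- compound 2 `N#Cc1cccc(Nc2ncnc3cc(NC(=O)/C=C/c4ccccc4)sc23)c1` gives 540 nM
- compound 3 `O=C(/C=C/c1ccccc1)Nc1cc2c(Nc3ccc(Cl)c(Cl)c3)ncnc2s1` gives 480 nM

In this assay, compound 2, at 540 nM, gives the highest of the three numbers, but it cannot be separated from the other two. Its value lies within the usual scatter of both compound 3 and compound 1, so the three compounds form a single narrow group.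

The next compound to be tested is compound 4 `O=C(/C=C/c1ccccc1)Nc1cc2ncnc(Nc3cc(Cl)cc(Cl)c3)c2s1`, which differs from compound 2 by one exchange: 3,5-dichlorophenyl in place of 3-cyanophenyl on a nitrogen on an aromatic ring. In words, 3,5-dichlorophenyl stands in place of 3-cyanophenyl on a nitrogen on an aromatic ring.

For the measured compounds named here, no measured step makes this exchange. Going by the values given here, the only step available is a 1.6-fold higher number from compound 1 to compound 3 (0.20 log units; within the scatter), which puts hydrogen in place of hydroxy on an aromatic carbon. That is a different change in a different place, and it stays within the scatter, so it bears on the question only weakly. Going by these compounds, with so little to go on, no step beyond the scatter is expected in this assay, and the direction remains open.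

The expected change is a 1.2-fold lower number from compound 2 to compound 4 (0.08 log units; within the scatter). For compound 4 the estimated value is 450 nM, with an expected range of 170 nM to 1200 nM.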

Compound 4, half-maximal inhibitory concentration: 220 nM
Compound 4: the middle estimate sits 2.0-fold (0.31 log units) above what was measured; the range from low to high includes it.
By their numbers in this assay, from the lowest: compounds 4, 1, 3 and 2 (each within the scatter of the next, the first and the last beyond it).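

In this assay, exchanging 3-cyanophenyl for 3,5-dichlorophenyl on a nitrogen on an aromatic ring gives a 2.5-fold lower number from compound 2 to compound 4 (0.39 log units; beyond the scatter). For the compounds shown here, this modest step lies beyond the scatter, whereas the only earlier step, a 1.6-fold higher number from compound 1 to compound 3 (0.20 log units; within the scatter), stayed within it and involved a different change in a different place, so this is the first sign that the aryl group on this nitrogen can shift the number. The two groups have the same count of heavy atoms and the same type of ring, so the step comes with a nitrile leaving and two chlorines entering rather than with a change in those counts, but nothing shown here explains the shift.

Going by these compounds, it remains open whether a single chlorine, as in 3-chlorophenyl, or a different pair of groups, as in 3,5-dimethoxyphenyl, on this nitrogen would give a number close to that of compound 4. On these data alone, it is also open whether a hydroxy group on the phenyl ring of the side chain of compound 4 would have any more effect than the within-scatter step seen on the core of compound 1.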